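Replacing the urea terminus of compound 1

The compounds below may be only part of what the source reports. "The series", "measured", "known", "first", "only" and "open" are said of these compounds alone.

Compound 1 `COc1ccc(-c2cnc3nc(N)nc(N4CCN(C(=O)NCc5ccc(F)cc5)CC4)c3n2)cc1OC` stands lowest of the two numbers in a functional assay on cells (T-cell, Homo sapiens) for inhibition (a higher number here means a weaker inhibitor, a lower number a stronger inhibitor), where compound 1 gives 37 nM. Compound 2 `COc1ccc(-c2cnc3nc(N)nc(NC4CCCC4)c3n2)cc1OC` gives 800 nM in this assay, a gap beyond the scatter. Compound 3 `CC(C)Oc1nc(N)nc2ncc(-c3ccc(C(F)(F)F)cc3)nc12` reaches only a limit and not a number in this assay, > 10000 nM, as noted in the limit of > 10000 nM in this assay, at which 1 of the 3 values shown sits. Compound 4 `COc1ccc(-c2cnc3nc(N)nc(N4CCN(C(=O)COc5ccc(Cl)cc5)CC4)c3n2)cc1OC` is not yet measured; it differs from compound 1 in one place, ((4-chlorophenoxy)methyl in place of (4-fluorobenzyl)amino on a carbonyl carbon), the carbonyl carbon and its amide-type nitrogen in a ring being kept. The step from compound 1 to compound 4 in this assay is expected to be small, no more than a modest weakening, a 1.6-fold higher number from compound 1 to compound 4 (0.21 log units; within the scatter). Compound 4 is accordingly estimated at 60 nM in this assay, within a range from 15 nM to 250 nM.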

Compound 4, half-maximal inhibitory concentration: 0.5 nM
Compound 4: middle estimate off by 120-fold (2.08 log units), on the high side; the whole stated range lies above it.
By their numbers in this assay, from the lowest: compound 4; then compound 1; then compound 2. At a limit, above all of these: compound 3.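

This place on the carbonyl carbon proves highly sensitive, and the urea terminus is not needed there: in this assay, (4-chlorophenoxy)methyl in place of (4-fluorobenzyl)amino gives a 74-fold lower number from compound 1 to compound 4 (1.87 log units; beyond the scatter). The entering group has 0 hydrogen-bond donors, so a donor in this group is not required for a low number. Nothing measured here gives a cause for this step.

Going by these compounds, the halogen and the linking atoms change together, so their shares in the step stay open. On these data alone, a (4-fluorophenoxy)methyl group would separate them, and a longer chain at this place remains untested in these data.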